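Chain shortening in a hydrazide series: notes toward compound 4

This account rests on a few compounds, and the source may have more. Where it says the series, first, only, none or still open, it means among the compounds named here.

Compound 1 `CCCCCCCCCCCCCCN(NC(=O)COC)C(=O)CCCCCCCCC` and compound 2 `CCCCCCCCCCN(NC(=O)COC)C(=O)CCCCCCCCC` share one core; compound 3 `CCCCCCCCCCCC/C=C/N(NC(=O)COC)C(=O)OC(C)(C)C` is built on a different core, and how the two cores differ is not broken down here. In an ADME assay on HUVEC cells (Homo sapiens) for antiproliferative activity, read by resazurin assay, with a stated time of 72 h (a lower number here means a stronger inhibitor of growth, a higher number a weaker inhibitor of growth), compound 1 gives 103000 nM and compound 2 gives 114000 nM. The structural change between them is hydrogen in place of butyl on a saturated chain carbon, ten or more bonds along the chain from an amide-type nitrogen and the step it made is a 1.1-fold higher number from compound 1 to compound 2 (0.04 log units; within the scatter), so the two numbers count as the same within the usual scatter.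

In this assay compound 3 gives 36100 nM, the lowest of the three numbers, with compound 1 the nearest and compound 2 the furthest, both beyond the scatter.

Compound 4 `CCCCCCCC/C=C/N(NC(=O)COC)C(=O)OC(C)(C)C` has not been measured. It differs from compound 3 by hydrogen in place of butyl on a saturated chain carbon, eight bonds along the chain from a double-bonded chain carbon. This is the same kind of change as that from compound 1 to compound 2, but not the same: the saturated chain carbon that carries it stands at a different place in the chain, as the two descriptions of the change show. Within the data shown here, on the single precedent, the step from compound 3 to compound 4 is expected to be a 1.2-fold higher number from compound 3 to compound 4 (0.07 log units; within the scatter), resting on a 1.1-fold higher number from compound 1 to compound 2 (0.04 log units; within the scatter). Compound 4 is therefore estimated at 42000 nM, expected to fall between 18000 nM and 100000 nM in this assay.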

Compound 4, concentration for 50% growth inhibition: 49900 nM
Compound 4: the middle estimate sits 1.2-fold (0.07 log units) below what was measured; the range from low to high includes it.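

In this assay the new step is a 1.4-fold higher number from compound 3 to compound 4 (0.14 log units; within the scatter), so on this core too, hydrogen in place of butyl gives two numbers that count as the same. Set beside the earlier step, the change carries from the core of compound 1 to the core of compound 3 with no difference that stands out from the scatter: the same change on two cores in this assay, a 1.1-fold higher number (0.04 log units; within the scatter) from compound 1 to compound 2 and a 1.4-fold higher number (0.14 log units; within the scatter) from compound 3 to compound 4, 1.2-fold (0.10 log units) apart, within the scatter of two such steps. Among these compounds, this rests on only two pairs, with the change at a different place in the chain in each, so it supports a small step on these two cores at these two places and does not show that the step stays small on any other core or elsewhere in the chain, nor does it give any reason for the small size of either step.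

Open, as far as these compounds go, is whether a chain shorter than that of compound 4 or longer than that of compound 3 would still give a number that counts as the same, and whether an amine or a carboxylic acid carried on the chain would shift it. Also open is which part of the difference between the two cores matters in this assay, as no pair shown differs in one place across them.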